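Sulfur-linked side chain: amide in place of amino alcohol

This account rests on a few compounds, and the source may have more. Where it says the series, first, only, none or still open, it means among the compounds named here.

Compound 1 `CC(C)c1n[nH]c2c(NCc3ccc(-c4ccccn4)cc3)nc(SCC(O)CN)nc12` gives 55 nM in a functional assay on HT cells (Homo sapiens) for antiproliferative activity, read by fluorescence, with a stated time of 72 h (on this read-out higher numbers stand for weaker inhibition of growth and lower numbers for stronger inhibition of growth), the lowest of the three numbers; compound 2 `CC(C)c1n[nH]c2c(NCc3ccc(-c4ccccn4)cc3)nc(SCC(C)(C)N)nc12` at 85 nM sits within the scatter of it, while compound 3 `CC(C)c1n[nH]c2c(NCc3ccc(-c4ccccn4)cc3)nc(SC3CCCCC3O)nc12` at 636 nM lies well beyond. Compound 4 `CC(C)c1n[nH]c2c(NCc3ccc(-c4ccccn4)cc3)nc(SCC(N)=O)nc12` differs from compound 1 in one place: carbamoyl in place of 2-amino-1-hydroxyethyl on a saturated chain carbon bound to a sulfur. Among the compounds with values here, two measured steps bear on this. Within the same side chain, a 1.5-fold higher number from compound 1 to compound 2 (0.19 log units; within the scatter), whereas a 12-fold higher number from compound 1 to compound 3 (1.06 log units; beyond the scatter). Compound 2 keeps an amino group on the chain; compound 3 and compound 4 do not. Compound 4 is therefore expected to sit nearer the side of compound 3, with a step of a 7.3-fold higher number from compound 1 to compound 4 (0.86 log units; beyond the scatter) beyond the scatter. The estimate for compound 4 is 400 nM, with a range of 150 nM to 1200 nM.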

Compound 4, concentration for 50% growth inhibition: 192 nM
The estimate for compound 4 lay 2.1-fold (0.32 log units) above the measured number; the measured number falls inside the stated range.
By their numbers in this assay, from the lowest: compounds 1 and 2 (each within the scatter of the next); then compound 4; then compound 3.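

In this assay the carbamoyl chain falls short of both amino-bearing chains, with a 3.5-fold higher number from compound 1 to compound 4 (0.54 log units; beyond the scatter) and a 2.3-fold higher number from compound 2 to compound 4 (0.35 log units; beyond the scatter), yet it improves on the 2-hydroxycyclohexyl chain, with a 3.3-fold lower number from compound 3 to compound 4 (0.52 log units; beyond the scatter). Among these compounds, then, a chain without an amino group need not fall as far as compound 3, so the presence or absence of that group does not alone set the order. Nothing measured here accounts for this order.

On these data alone, it remains open whether a carboxylic acid in place of carbamoyl, or a longer chain ending in carbamoyl, would sit nearer compound 1 or compound 3.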